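The source may hold more compounds than are shown below. What is called first, only, known or untested is meant among the compounds shown, and "the series" means these compounds.

Three compounds that share one core, and differ only in the aromatic group on a carbon with a double bond to nitrogen, have been measured in a functional assay on A549 cells (Homo sapiens) for cytotoxicity, read by MTT assay, with a stated time of 72 h; a higher number here means a weaker inhibitor, a lower number a stronger inhibitor. Compound 1 (`COc1cc2ncnc(Nc3ccc(F)c(Cl)c3)c2cc1NC(=O)N/N=C/c1ccc(F)cc1`) gives 26600 nM. Compound 2 (`COc1cc2ncnc(Nc3ccc(F)c(Cl)c3)c2cc1NC(=O)N/N=C/c1cccc(Br)c1`) gives 28100 nM. Compound 3 (`COc1cc2ncnc(Nc3ccc(F)c(Cl)c3)c2cc1NC(=O)N/N=C/c1ccc(OC)c(OC)c1OC`) gives 32800 nM, which places it level with the other two once the usual scatter of repeated measurements is allowed for.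

The untested compound 4 (`COc1cc2ncnc(Nc3ccc(F)c(Cl)c3)c2cc1NC(=O)N/N=C/c1cc(Br)c(O)c(Br)c1`) keeps the core, but 3,5-dibromo-4-hydroxyphenyl takes the place of 2,3,4-trimethoxyphenyl on a carbon with a double bond to nitrogen: 3,5-dibromo-4-hydroxyphenyl in place of 2,3,4-trimethoxyphenyl on a carbon with a double bond to nitrogen.

Among the measured compounds shown here, three measured steps bear on this change, since all of them swap the group at that same place. They are a 1.1-fold higher number from compound 1 to compound 2 (0.02 log units; within the scatter), a 1.2-fold higher number from compound 1 to compound 3 (0.09 log units; within the scatter) and a 1.2-fold higher number from compound 2 to compound 3 (0.07 log units; within the scatter). Each lies within the scatter, so among these three compounds, exchanging one aromatic group for another has not moved the number. None of them carries the 3,5-dibromo-4-hydroxyphenyl group itself, so this evidence is indirect and the range must stay wide.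

The expected change is therefore none beyond the scatter, and the estimate is a 1.2-fold lower number from compound 3 to compound 4 (0.07 log units; within the scatter). For compound 4 the estimated value is 28000 nM, with an expected range from 12000 nM to 60000 nM.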

Compound 4, half-maximal inhibitory concentration: 34600 nM
Compound 4: middle estimate off by 1.2-fold (0.09 log units), on the low side; low and high end bracket the measured number.
By their numbers in this assay, from the lowest: compounds 1, 2, 3 and 4 (each within the scatter of the next).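

Among the compounds shown here, compound 4 tests a more drastic exchange than the earlier compounds did: in this assay, its 3,5-dibromo-4-hydroxyphenyl group brings bromine and a hydroxyl together on one ring, and it replaces a group with no hydrogen-bond donor with one that has a hydrogen-bond donor. Even so, a 1.1-fold higher number from compound 3 to compound 4 (0.02 log units; within the scatter) and a 1.2-fold higher number from compound 2 to compound 4 (0.09 log units; within the scatter) and a 1.3-fold higher number from compound 1 to compound 4 (0.11 log units; within the scatter) all lie within the scatter, so the level result now holds across four differently substituted aromatic groups on a carbon with a double bond to nitrogen. Nothing shown here explains why these groups give such similar numbers.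

Going by these compounds, all four compounds carry a benzene ring at this place, so it remains open whether a pyridine ring, a cyclohexyl ring, or a phenyl ring bearing a carboxylic acid or a dimethylamino group would shift the number. The shared core is also unchanged throughout, which leaves open what a change there would do and whether these groups would still give level numbers on a different core.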